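Trimming the side chain of compound 2: working notes

A few compounds are considered here, and "the series" means these few. Any claim that something is new, unique, unknown or untested is made for them only; others in the source may bear on it.

Measured so far:
Compound 1 `COC(c1cc(Cl)c2c(c1Cl)C(=O)N(Cc1c(C)cc(C)[nH]c1=O)CC2)C1CCOC1` in a functional assay on KARPAS-422 cells (Homo sapiens) for antiproliferative activity, read by resazurin assay, with a stated time of 72 h (on this read-out lower numbers stand for stronger inhibition and higher numbers for weaker inhibition), gives 175 nM; 406 nM; 50 nM; 25 nM (4 entries).
Compound 2 `Cc1cc(C)c(CN2CCc3c(Cl)cc([C@H](CO)[C@H]4CCOC4)c(Cl)c3C2=O)c(=O)[nH]1` in this assay gives 15 nM.

The entries of compound 1 spread widely (the several entries of compound 1 in this assay, 175 nM; 406 nM; 50 nM; 25 nM (4 entries)). Compound 2 stands at the only single number shown for it; one further entry carries no single number. Compound 3 `Cc1cc(C)c(CN2CCc3c(Cl)cc([C@H](C)CO)c(Cl)c3C2=O)c(=O)[nH]1` is not yet measured. The change from compound 2: a group of 4 heavy atoms (3 carbon, 1 oxygen; no ring) in place of a group of 8 heavy atoms (6 carbon, 2 oxygen; one five-membered non-aromatic ring with 1 hetero atom), on an aromatic carbon — the 1-(hydroxymethyl)ethyl group takes the place of the larger group holding the five-membered non-aromatic ring with 1 hetero atom. Among the compounds with values here, no measured pair covers a change of this kind. A step toward weaker inhibition, beyond the scatter, is expected, a 4.7-fold higher number from compound 2 to compound 3 (0.67 log units; beyond the scatter). Compound 3 is expected to give 70 nM, between 20 nM and 300 nM.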

Compound 3, half-maximal inhibitory concentration: 186 nM
Compound 3: the middle estimate sits 2.7-fold (0.42 log units) below what was measured, and the stated range covers the measured number.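

Within the data shown here, this is the first step read at this aromatic carbon: in this assay, the 1-(hydroxymethyl)ethyl group in place of the larger group holding the five-membered non-aromatic ring gives a 12-fold higher number from compound 2 to compound 3 (1.09 log units; beyond the scatter). Both groups carry one hydrogen-bond donor, so keeping that count does not keep the value of compound 2. The step rests on single entries, and entries for one compound in this series can spread widely: the several entries of compound 1 in this assay, 175 nM; 406 nM; 50 nM; 25 nM (4 entries)

Open, as far as these compounds go, is whether the ring itself or the heavy-atom count tracks the value. A cyclopropyl group or a longer open chain at this carbon would separate the two.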